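The source may report more compounds than this note shows. Statements on the series, on what has been measured and on what is new or still open speak of the compounds shown alone.

In a functional assay on MCF7 cells (Homo sapiens) for inhibition, read by MTT assay, with stated times of 18 h and 4 h (a higher number here means a weaker inhibitor, a lower number a stronger inhibitor), compound 3 (`CCCCCCCCOP(=O)(O)OCCSC(=S)N1CCCCCC1`) gives 78000 nM. Compound 2 (`CCCCCCCCCCOP(=O)(O)OCCSC(=S)N1CCCCCC1`) gives 43300 nM, and these two values lie within the scatter of each other. Compound 1 (`CCCCCCCCCCCCCCCCOP(=O)(O)OCCSC(=S)N1CCCCCC1`) reads > 100000 nM, which is a limit of the assay and not a number. The three compounds share one core and differ only in the length of the saturated chain.

Compound 4 (`CCCCCCOP(=O)(O)OCCSC(=S)N1CCCCCC1`) keeps that core and shortens the chain again. The change is hydrogen in place of ethyl on a saturated chain carbon, six bonds along the chain from an oxygen on an unsaturated carbon.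

The closest measured change is also hydrogen in place of ethyl, and it gave a 1.8-fold higher number from compound 2 to compound 3 (0.26 log units; within the scatter). The larger cuts point the other way, with an at least 2.3-fold lower number from compound 1 to compound 2 (0.36 log units; beyond the scatter) and an at least 1.2-fold lower number from compound 1 to compound 3 (0.10 log units; that floor lies within the scatter). Compound 1 therefore goes against any rule that a shorter chain means a higher number, so chain length gives no firm direction here.

In this assay, no change beyond the scatter is expected, at most a slight rise. The expected step is a 1.2-fold higher number from compound 3 to compound 4 (0.06 log units; within the scatter). Compound 4 is estimated at 90000 nM, with an expected range of 40000 nM to 150000 nM.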

Compound 4, half-maximal inhibitory concentration: 55000 nM
Estimate against measurement, compound 4: 1.6-fold (0.21 log units) above; measured number inside the range.
By their numbers in this assay, from the lowest: compounds 2, 4 and 3 (each within the scatter of the next). At a limit, above all of these: compound 1.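

In this assay, hydrogen in place of ethyl on a saturated chain carbon, six bonds along the chain from an oxygen on an unsaturated carbon, gives a 1.4-fold lower number from compound 3 to compound 4 (0.15 log units; within the scatter), and hydrogen in place of butyl at that same place gives a 1.3-fold higher number from compound 2 to compound 4 (0.10 log units; within the scatter). Among the compounds shown here, compound 2, compound 3 and compound 4 therefore cannot be told apart in this assay, so the shorter chain in compound 4 opens no gap from the two chains before it, something the single pair of compound 2 and compound 3 could not show. The comparison with the longest chain gives an at least 1.8-fold lower number from compound 1 to compound 4 (0.25 log units; that floor lies within the scatter), so even this step does not separate the two compounds, and it rests on a value of compound 1 that is a limit of the assay and not a number: the limit of > 100000 nM in this assay, at which 1 of the 4 values shown sits.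

The compounds shown leave open whether a still shorter chain, or a chain carrying an amine or a carboxylic acid, would stand apart from compound 4 in this assay. They also leave open whether these chains would stay as close together in another cell line.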